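Amide variation on the shared core: toward the unsubstituted phenyl

The source may report more compounds than this note shows. Statements on the series, on what has been measured and on what is new or still open speak of the compounds shown alone.

The series rests on the core shown in compound 1 `COc1cc(-c2nn(-c3cccc(NC(=O)Nc4ccc(Cl)c(Cl)c4)c3)cc2-c2ccncc2)ccc1Cl`, which in a functional assay on RXF 393 cells (Homo sapiens) for inhibition, read by sulforhodamine B assay, with a stated time of 48 h (a higher number here means a weaker inhibitor of growth, a lower number a stronger inhibitor of growth), gives 2440 nM. Within the data shown here, compound 2 `COc1cc(-c2nn(-c3cccc(NC(=O)c4ccc(Cl)c(C(F)(F)F)c4)c3)cc2-c2ccncc2)ccc1Cl` carries an amide instead of the urea and in this assay gives 18700 nM, the highest of the two numbers measured so far; its nearest neighbour is compound 1, the step of a 7.7-fold higher number from compound 1 to compound 2 (0.88 log units; beyond the scatter) being beyond the scatter.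

Compound 3 `COc1cc(-c2nn(-c3cccc(NC(=O)c4ccccc4)c3)cc2-c2ccncc2)ccc1Cl` is not yet measured. It differs from compound 2 by phenyl in place of 4-chloro-3-(trifluoromethyl)phenyl on a carbonyl carbon. Among the measured compounds shown here, the only measured step that touches this part of the molecule is the one from compound 1 to compound 2, which also changed the linker, so it does not isolate the effect of the ring substituents. For the measured compounds named here, no measured pair shows what removing chlorine and trifluoromethyl from this ring does. The expectation for compound 3 in this assay therefore rests on compound 2 alone, with wide uncertainty, and a step of a 1.3-fold higher number from compound 2 to compound 3 (0.13 log units; within the scatter) toward a somewhat higher number is expected, not beyond what the scatter could absorb. Compound 3 is estimated at 25000 nM, within 8000 nM to 80000 nM.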

Compound 3, concentration for total growth inhibition: 6340 nM
Estimate against measurement, compound 3: 3.9-fold (0.60 log units) above, and the stated range ends above it.
By their numbers in this assay, from the lowest: compound 1; then compound 3; then compound 2.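

In this assay, the change at the carbonyl carbon gives a 2.9-fold lower number from compound 2 to compound 3 (0.47 log units; beyond the scatter), so on this amide the plain phenyl gives a lower number than the 4-chloro-3-(trifluoromethyl)phenyl, and the chlorine and trifluoromethyl are not needed to reach that level of growth inhibition. Replacing the (3,4-dichlorophenyl)amino of the urea with phenyl gives a 2.6-fold higher number from compound 1 to compound 3 (0.41 log units; beyond the scatter), so compound 1 keeps the lowest number of the three, while the printed values place compound 3 between compound 1 and compound 2, and the loss seen on leaving the urea depends on which ring the amide carries. Nothing at hand speaks to why the numbers fall in this order.

Chlorine and trifluoromethyl leave together in this step, so a phenyl bearing only chlorine or only trifluoromethyl would be needed to show whether one of them accounts for the rise in compound 2, and a urea with an unsubstituted phenylamino group would show whether the urea keeps its lower number without the two chlorines. Also open, from the compounds shown here alone, is how this position responds to a group of another kind on the phenyl ring, such as an amine or a carboxylic acid.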